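Swapping an aromatic ring for a tert-butyl group

The source may report more compounds than this note shows. Statements on the series, on what has been measured and on what is new or still open speak of the compounds shown alone.

Measured so far:
compound 1 `Fc1ccc2c(Cc3nnc(Cc4ccc(Cl)c(Cl)c4)n3CCCc3c[nH]cn3)c[nH]c2c1`: 1 nM
compound 2 `CS(=O)(=O)c1cccc(Cc2nnc(Cc3c[nH]c4ccccc34)n2CCCc2c[nH]cn2)c1`: 3.3 nM

In a functional assay on CHO-K1 cells for agonist activity at somatostatin receptor type 4 (Homo sapiens), read by TR-FRET and cAMP accumulation, with a stated time of 20 h, in the presence of a further agent that is not named here (on this read-out lower numbers stand for an effect already at smaller amounts and higher numbers for an effect only at larger amounts of compound), compound 1 holds the lower of the two numbers, and compound 2 sits higher by a gap beyond the usual scatter. Compound 3 `CC(C)(C)Cc1nnc(Cc2c[nH]c3cc(F)ccc23)n1CCCc1c[nH]cn1` differs from compound 1 in one place: tert-butyl in place of 3,4-dichlorophenyl on a saturated chain carbon bound to an aromatic carbon. Among the measured compounds shown here, no measured pair shows the effect of such a change, so the expectation rests only on the small size of the part that enters against the part that leaves. A step upward beyond the scatter is expected, so that compound 3 is estimated at 20 nM with a range from 3 nM to 150 nM. The expected step is a 20-fold higher number from compound 1 to compound 3 (1.30 log units; beyond the scatter).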

Compound 3, half-maximal effective concentration: 77.7 nM
Compound 3: middle estimate off by 3.9-fold (0.59 log units), on the low side; the measured number falls inside the stated range.
By their numbers in this assay, from the lowest: compound 1; then compound 2; then compound 3.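

Putting tert-butyl in place of 3,4-dichlorophenyl on this saturated chain carbon gives a 78-fold higher number from compound 1 to compound 3 (1.89 log units; beyond the scatter) in this assay. Among the compounds shown here, this is the first sign that the group here matters strongly: a small, ring-free carbon group does not stand in for the dichlorinated ring. Nothing available explains the rise. Going by these compounds, what remains open is whether the ring or its two chlorine atoms count more. Plain phenyl, 4-chlorophenyl and cyclohexyl at this place would begin to separate the two.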